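The source may report more compounds than this note shows. Statements on the series, on what has been measured and on what is new or still open speak of the compounds shown alone.

Measured in a functional assay on MCF7 cells (Homo sapiens) for antiproliferative activity, read by WST assay, with a stated time of 3 days; on this read-out lower numbers stand for stronger inhibition and higher numbers for weaker inhibition:
- Compound 1 `[N-]=[N+]=Nc1cc(=O)[nH]c(=O)n1[C@@H]1O[C@H](CO)[C@@H](O)[C@H]1O`: > 50000 nM, a limit
- Compound 2 `CN(C)c1cc(=O)[nH]c(=O)n1[C@@H]1O[C@H](CO)[C@@H](O)[C@H]1O`: > 50000 nM, a limit

Compound 1 is known only through a limit, not a number: the limit of > 50000 nM in this assay, at which 2 of the 2 values shown sit. Compound 3 `[N-]=[N+]=Nc1c(F)c(=O)[nH]c(=O)n1[C@@H]1O[C@H](CO)[C@@H](O)[C@H]1O` has fluoro in place of hydrogen on an aromatic carbon, ortho to an azido group: fluoro in place of hydrogen on an aromatic carbon. Within the data shown here, the only measured step, a step that the two limits leave unreadable from compound 1 to compound 2, replaces the azido group instead and gives no size to carry over. No step beyond the scatter can therefore be expected with confidence in this assay. The expected step, weakly founded, is an at least 1.2-fold lower number from compound 1 to compound 3 (0.09 log units; that floor lies within the scatter). Compound 3 is estimated at 40000 nM, with an expected range of 5000 nM to 100000 nM.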

Compound 3, half-maximal inhibitory concentration: 1000 nM
Compound 3: the middle estimate sits 40-fold (1.60 log units) above what was measured; measured number outside the range, below it.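

In this assay, fluoro in place of hydrogen on an aromatic carbon, ortho to an azido group, gives an at least 50-fold lower number from compound 1 to compound 3 (1.69 log units; beyond the scatter), so this single added atom turns a compound without a readable value into one with a number. The size is a floor and not a measured gap, since compound 1 is known only through a limit: the limit of > 50000 nM in this assay, at which 2 of the 3 values shown sit. The step from compound 1 to compound 2 cannot be read, so this position is the only place in the series with a readable effect.

Going by these compounds, whether chloro, methyl or an amine at this position would do the same stays open. So does whether fluoro acts alike with the dimethylamino group of compound 2 in place of the azido group.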